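The source may report more compounds than this note shows. Statements on the series, on what has been measured and on what is new or still open speak of the compounds shown alone.

Measured in a physicochemical assay for metabolic stability, read by LC-MS, with a stated time of 38 days, tested at 10 mM; on this read-out lower numbers stand for a less stable compound and higher numbers for a more stable compound:
compound 1 `Cc1ccc(-c2cc(C(=O)Nc3nnc(-c4ccncc4)s3)c3ccccc3c2)o1` gives 25%
compound 2 `Cc1ccc(-c2cc(C(=O)NC(C)C3CCCO3)c3ccccc3n2)o1` gives 55%
compound 3 `Cc1cccc(NC(=O)c2cc(-c3ccc(C)o3)nc3ccccc23)n1` gives 73%

Compound 3 stands highest of the three at 73%, beyond the scatter from both others. Next comes compound 4 `Cc1ccc(-c2cc(C(=O)NC3CCCCC3)c3ccccc3n2)o1`, not yet measured: cyclohexyl in place of 6-methylpyridin-2-yl on an amide-type nitrogen, with cyclohexyl in place of 6-methylpyridin-2-yl on an amide-type nitrogen. For the measured compounds named here, one measured step bears on this change: a number 18 percentage points higher from compound 2 to compound 3 (beyond the scatter), modest in size and also made on that nitrogen, with 6-methylpyridin-2-yl entering. Losing that group is therefore expected to give a fall of similar size, although cyclohexyl itself has no measurement yet. The expected change in this assay is a number 15 percentage points lower from compound 3 to compound 4 (beyond the scatter). For compound 4 the estimate is 58%, with an expected range of 40% to 76%.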

Compound 4, percent of the compound remaining: 54%
Estimate against measurement, compound 4: 4 percentage points above; low and high end bracket the measured number.
By their numbers in this assay, from the lowest: compound 1; then compounds 4 and 2 (each within the scatter of the next); then compound 3.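

In this assay cyclohexyl on the amide-type nitrogen gives a number 19 percentage points lower from compound 3 to compound 4 (beyond the scatter) and also a number 1 percentage points lower from compound 2 to compound 4 (within the scatter). Of the three groups compared on this nitrogen, 6-methylpyridin-2-yl alone stands apart, while cyclohexyl and 1-(oxolan-2-yl)ethyl do not separate. Nothing at hand explains this difference.

On these data alone, it remains open whether the ring nitrogen or the methyl of 6-methylpyridin-2-yl goes with the higher number. Plain pyridin-2-yl and 3-methylphenyl on this nitrogen would separate the two.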